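The source may hold more compounds than are shown below. What is called first, only, known or untested is meant among the compounds shown, and "the series" means these compounds.

Compound 1 `CC(=O)n1nc(C)c(-c2ccc(Cl)c(Cl)c2)c1N`: > 100000 nM
Compound 2 `CCc1nn(C(C)=O)c(N)c1-c1ccc(Cl)c(Cl)c1`: > 100000 nM

In an assay on Sf9 cells for inhibition of inhibitor of nuclear factor kappa-B kinase subunit epsilon (Homo sapiens), read by ADP-Glo, with a stated time of 60 min (on this read-out higher numbers stand for weaker inhibition and lower numbers for stronger inhibition), compound 1 gives only a limit of the assay, not a number. It therefore stands at the limit of > 100000 nM in this assay, at which 2 of the 2 values shown sit, the same point where compound 2 also sits. Compound 3 `CCNC(=O)n1nc(C)c(-c2ccc(Cl)c(Cl)c2)c1N` differs from compound 1 by ethylamino in place of methyl on a carbonyl carbon, which reads, cut one bond further out, as acetyl to ethylcarbamoyl. For the measured compounds named here, the only measured step, a step that the two limits leave unreadable from compound 1 to compound 2, cannot be read because both values are limits, so no measured step bears on this change. No step beyond the scatter is expected in this assay. Compound 3 is therefore expected to give about 150000 nM, between 30000 nM and 600000 nM, an estimated step that the limit leaves unreadable from compound 1 to compound 3.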

Compound 3, half-maximal inhibitory concentration: > 100000 nM
Compound 3 ended at the assay's limit; the forecaster's own chance of this, stated with the estimate: 80%; the middle value is on the limit's open side.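

No step can be read between compound 1 and compound 3, since each gives only a limit and not a number: the limit of > 100000 nM in this assay, at which 3 of the 3 values shown sit.

The compounds shown leave open how compound 1, compound 2 and compound 3 rank against one another.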